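This account rests on a few compounds, and the source may have more. Where it says the series, first, only, none or still open, it means among the compounds named here.

Notes on the series, read in a physicochemical assay for acid dissociation, throughout. Compound 1 (`NS(=O)(=O)c1ccc(SCCO)c(F)c1`) gives 9.76 and stands clear of the other two numbers. Compound 2 (`NS(=O)(=O)c1ccc(S(=O)(=O)CCO)c(F)c1`) gives 9 and compound 3 (`COC(=O)c1cc(S(N)(=O)=O)ccc1S(=O)(=O)CCO`) gives 9.2 so that compound 3 sits within the scatter of compound 2 and beyond the scatter under compound 1.

The next compound is compound 4 (`COC(=O)c1cc(S(N)(=O)=O)ccc1S(=O)(=O)CCCO`). The change is hydroxymethyl in place of hydroxy on a saturated chain carbon, two bonds along the chain from a sulfonyl sulfur and it reads equally as (2-hydroxyethyl)sulfonyl to (3-hydroxypropyl)sulfonyl.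

Among the measured compounds shown here, the only measured step between compounds differing in one place is a number 0.20 log units higher from compound 2 to compound 3 (within the scatter) and it concerns an aromatic carbon, not the chain. For the measured compounds named here, no measured step therefore speaks directly to this change, and the one available stayed inside the scatter. No step beyond the scatter is expected in this assay here. The expected step is a number 0.05 log units higher from compound 3 to compound 4 (within the scatter) and it carries no firm direction. For compound 4 the estimate is 9.25 with an expected range of 8.95 to 9.55 in this read-out.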

Compound 4, acid dissociation constant: 8.9
Compound 4: the middle estimate sits 0.35 log units above what was measured; measured number below the stated range.
By their numbers in this assay, from the lowest: compounds 4, 2 and 3 (each within the scatter of the next); then compound 1.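

In this assay, hydroxymethyl in place of hydroxy on a saturated chain carbon, two bonds along the chain from a sulfonyl sulfur, gives a number 0.30 log units lower from compound 3 to compound 4 (within the scatter). Among the compounds shown here, this is the first reading at the chain itself, since the earlier step concerned an aromatic carbon, and this single pair gives no firm direction for (2-hydroxyethyl)sulfonyl to (3-hydroxypropyl)sulfonyl. No supporting data bear on the reason for this reading.

Going by these compounds, whether the same change gives a step of similar size on the core of compound 2 remains open. Also open, on these data alone, is how this assay would read with a longer chain than 3-hydroxypropyl, or with an amine or a carboxylic acid in place of the hydroxy, and whether any of these would give a step beyond the scatter.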